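From fluoro to methyl on an aromatic ring

A few compounds are considered here, and "the series" means these few. Any claim that something is new, unique, unknown or untested is made for them only; others in the source may bear on it.

Compound 1 `CCn1c([C@@H](C)NS(=O)(=O)C2CC2)nc2ccc(C(F)(F)F)cc21`, compound 2 `CCn1c([C@@H](C)NS(=O)(=O)c2ccccc2)nc2ccc(C(F)(F)F)cc21` and compound 3 `CCn1c([C@@H](C)NS(=O)(=O)c2ccc(F)cc2)nc2ccc(C(F)(F)F)cc21` differ only in the group on the sulfonyl sulfur, and all three were tested in an ADME assay (liver) for metabolic stability, with Liver microsome (Homo sapiens) as the target, read by LC-MS, using microsomes and NADPH, with a stated time of 5 min, at 37 degrees C; a higher number here means faster removal of the compound, a lower number slower removal. Compound 1 gives < 3 mL.min-1.g-1, which is a limit of the assay and not a number. Compound 2 gives 14 mL.min-1.g-1 and compound 3 gives 26 mL.min-1.g-1, two values within the scatter of each other. Compound 3 therefore stands level with compound 2. Replacing cyclopropyl with an aromatic ring produced clear steps: an at least 4.6-fold higher number from compound 1 to compound 2 (0.66 log units; beyond the scatter) and an at least 8.6-fold higher number from compound 1 to compound 3 (0.93 log units; beyond the scatter).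

Compound 4 `CCn1c([C@@H](C)NS(=O)(=O)c2ccc(C)cc2)nc2ccc(C(F)(F)F)cc21` has methyl in place of fluoro on an aromatic carbon. Within the data shown here, no measured step makes this exact swap. Compound 4 keeps the aromatic ring, so the two large steps from cyclopropyl offer little guidance. The closest guide is the change at the same carbon, a 1.9-fold higher number from compound 2 to compound 3 (0.27 log units; within the scatter), which is small. A similarly small change, with no shift beyond the scatter, is therefore expected in this assay. The expected step is a 1.2-fold higher number from compound 3 to compound 4 (0.06 log units; within the scatter). Compound 4 is estimated at 30 mL.min-1.g-1, within an expected range of 12 mL.min-1.g-1 to 70 mL.min-1.g-1.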

Compound 4, intrinsic clearance in microsomes: > 100 mL.min-1.g-1
Compound 4: no number, only a limit (the forecaster's own chance of this, stated with the estimate: 3%); middle value at least 3.3-fold (0.52 log units) away from the limit.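

Among these compounds, the carbon para to a large group matters more in this assay than the earlier compounds suggested: hydrogen and fluoro there gave values within the scatter of each other, whereas methyl brings an at least 3.8-fold higher number from compound 3 to compound 4 (0.58 log units; beyond the scatter) and an at least 7.1-fold higher number from compound 2 to compound 4 (0.85 log units; beyond the scatter). The value of compound 4 is a limit of the assay and not a number: the limit of > 100 mL.min-1.g-1 in this assay, at which 1 of the 4 values shown sits.

Among the compounds shown here, the change from cyclopropyl on the sulfonyl sulfur, already clear with the plain and the fluorinated aromatic rings, now reaches an at least 33-fold higher number from compound 1 to compound 4 (1.52 log units; beyond the scatter), the only step in this set marked as large, and the single difference that sets this compound apart from compound 3 is one heavy atom on the ring.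

On these data alone, how far compound 4 lies beyond its limit stays open, and so does whether the removal of the compound involves the methyl group itself. The compounds shown cannot tell whether the same jump would come with a trifluoromethyl, a chlorine, a methoxy or a longer chain such as ethyl at this carbon.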